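Dropping the methoxy group from compound 2

The source may hold more compounds than are shown below. What is called first, only, known or untested is meant among the compounds shown, and "the series" means these compounds.

Measured so far:
compound 1, `COc1ccc(-c2nc(SCC(=O)c3sc(-c4ccccc4)nc3C)nc(N)c2C#N)cc1`: 68.8%
compound 2, `COc1ccc(-c2nc(C)c(C(=O)CSc3nc(N)c(C#N)c(-c4ccc(Cl)cc4)n3)s2)cc1`: 51.4%

Of the compounds shown here, two have been tested in a functional assay on U-87MG ATCC cells for antiproliferative activity against U-87 MG (Homo sapiens), read by MTT assay, with a stated time of 48 h, tested at 5 uM; a lower number here means a stronger effect, a higher number a weaker effect of the compound at the concentration tested. Compound 2 stands lowest of the two numbers; its nearest neighbour, compound 1, lies higher by a gap that is beyond the usual scatter. The two structures differ in more than one place, so their values alone are all that can be said of them.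

The next compound, compound 3, `Cc1nc(-c2ccccc2)sc1C(=O)CSc1nc(N)c(C#N)c(-c2ccc(Cl)cc2)n1`, is reached from compound 2 by a single change: hydrogen in place of methoxy on an aromatic carbon. Within the data shown here, no step between measured compounds separates this change from others, so its effect has no precedent here. In this assay one small methoxy-to-hydrogen exchange is expected to give a step of modest size, in either direction, most likely none beyond the scatter.

For compound 3 the estimated value is 55%, in a range from 40% to 72%. The step this estimate implies, a number 3.6 percentage points higher from compound 2 to compound 3 (within the scatter), is expected to stay within the scatter.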

Compound 3, a percentage reported as activity, at one concentration (the size of the read-out at that concentration, not a potency): 62.9%
Compound 3: middle estimate off by 7.9 percentage points, on the low side; low and high end bracket the measured number.
By their numbers in this assay, from the lowest: compound 2; then compounds 3 and 1 (each within the scatter of the next).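

In this assay, the change from 4-methoxyphenyl to phenyl gives the first step read at this position, a number 11.5 percentage points higher from compound 2 to compound 3 (beyond the scatter), so the methoxy group here is not interchangeable with hydrogen, and compound 2, which carries it, gives the lower number. At the other six-membered aromatic ring, chloro in place of methoxy gives a number 5.9 percentage points lower from compound 1 to compound 3 (within the scatter), so that exchange does not separate compound 1 from compound 3 in this read-out. Nothing available here accounts for either step.

As far as these compounds go, it remains open whether the step at the first position is specific to methoxy, or whether a hydroxyl group, an ethoxy group or an amine there would give a similar number. From the compounds shown here alone, it is also open whether the step holds when the other ring carries methoxy instead of chloro.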